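Placing a Methyl-Oxazolyl Group on the Sulfonamide Nitrogen

The source may report more compounds than this note shows. Statements on the series, on what has been measured and on what is new or still open speak of the compounds shown alone.

Measured so far:
Compound 1, `NS(=O)(=O)c1ccc(NC2=NC(=O)/C(=C\c3coc4ccccc4c3=O)S2)cc1`: 8910 nM
Compound 2, `Cc1cc(C)nc(NS(=O)(=O)c2ccc(NCc3coc4ccccc4c3=O)cc2)n1`: 93600 nM

Two compounds have numbers in a functional assay on MCF7 cells (Homo sapiens) for cytotoxicity, read by sulforhodamine B assay, with a stated time of 72 h; a higher number here means a weaker inhibitor, a lower number a stronger inhibitor. Compound 1 stands at the lower of the two, so it is the stronger inhibitor of the pair; compound 2 sits well above it, beyond the scatter. Compound 2 differs from compound 1 in more than one place, however, so its higher number cannot be tied to any single change.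

Compound 3, `Cc1cc(NS(=O)(=O)c2ccc(NC3=NC(=O)/C(=C\c4coc5ccccc5c4=O)S3)cc2)no1`, has not yet been measured. It differs from compound 1 in one place only: 5-methyl-1,2-oxazol-3-yl in place of hydrogen on a sulfonamide nitrogen. Within the data shown here, no measured pair shows this change on its own. Compound 2 also carries a ring on its sulfonamide nitrogen, but its linker to the shared core differs as well, so its number gives no clean guide. With nothing in the data pointing firmly either way, the step from compound 1 to compound 3 is expected to be small, near the scatter, and is estimated as a 1.3-fold higher number from compound 1 to compound 3 (0.13 log units; within the scatter). Compound 3 is therefore estimated at 12000 nM, with an expected range from 3000 nM to 50000 nM.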

Compound 3, half-maximal inhibitory concentration: > 100000 nM
Compound 3: a limit, no number; the forecaster's own chance of this, stated with the estimate: 10%; middle value at least 8.3-fold (0.92 log units) away from the limit.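

For compound 3 the reading in this assay is a limit of the assay and not a number: the limit of > 100000 nM in this assay, at which 1 of the 3 values shown sits. Even so, this single change on the sulfonamide nitrogen gives an at least 11-fold higher number from compound 1 to compound 3 (1.05 log units; beyond the scatter), so the position is sensitive to what it carries: placing 5-methyl-1,2-oxazol-3-yl there, in place of hydrogen, costs clear activity in these cells. The earlier compounds shown here could not show this, as they differ from each other in more than one place, whereas here the core of compound 1 is kept and only the group on this nitrogen changes.

As far as these compounds go, with a single group on this nitrogen, it stays open whether the loss belongs to this particular ring or would follow from any group placed there, and a small group such as a methyl or an acetyl on the same nitrogen would help separate the two. From the compounds shown here alone, how far the step extends past its printed size also remains unknown, since only its lower bound can be read.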